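Compound 3 to compound 4: methoxy to hydroxy

The compounds below may be only part of what the source reports. "The series", "measured", "known", "first", "only" and "open" are said of these compounds alone.

Measured in a functional assay on SH-SY5Y cells (Homo sapiens) for cytotoxicity, read by MTT assay, with a stated time of 48 h; on this read-out lower numbers stand for stronger inhibition and higher numbers for weaker inhibition:
- compound 1 `COc1cc(/C=C/C(=O)/C=C/c2nc3c(C)cccc3n2C)ccc1O` gives 1000 nM
- compound 2 `COc1ccc2c(c1)nc(/C=C/C(=O)/C=C/c1ccc(O)c(OC)c1)n2C` gives 4800 nM
- compound 3 `COc1ccc2c(c1)nc(/C=C/C(=O)/C=C/c1ccc(OC)c(O)c1)n2C` gives 4800 nM

Compound 3 stands level with compound 2, together the highest of the three numbers, and compound 1 lies lower. Compound 4 `COc1ccc(/C=C/C(=O)/C=C/c2nc3cc(O)ccc3n2C)cc1O` differs from compound 3 by hydrogen in place of methyl on an oxygen on an aromatic ring. Going by the values given here, the one measured step, no change at the digits printed from compound 2 to compound 3 (within the scatter), is a different exchange and bears only loosely on this one. Among the compounds with values here, with that step as the sole guide, no change beyond the scatter is expected in this assay, the expected step being a 1.2-fold lower number from compound 3 to compound 4 (0.08 log units; within the scatter). Compound 4 is estimated at 4000 nM, with an expected range from 1500 nM to 11000 nM.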

Compound 4, half-maximal inhibitory concentration: 4600 nM
For compound 4 the middle estimate is 1.2-fold (0.06 log units) below the measured one; low and high end bracket the measured number.
By their numbers in this assay, from the lowest: compound 1; then compounds 4, 2 and 3 (each within the scatter of the next).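

In this assay, hydrogen in place of methyl on the oxygen on the core's aromatic ring reads as a 1.0-fold lower number from compound 3 to compound 4 (0.02 log units; within the scatter). The earlier compounds shown here tested only an exchange on the phenyl ring; this result shows that the methyl on this core oxygen can give way to hydrogen with no change beyond the scatter. No supporting data bear on why this is so.

On these data alone, whether an amine, a carboxylic acid or a longer alkoxy chain at this place would hold the number remains open. Also open, as far as these compounds go, is which of its several differences sets compound 1 at 1000 nM.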